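Swapping the Amide's Aromatic Ring in Compound 2

This account rests on a few compounds, and the source may have more. Where it says the series, first, only, none or still open, it means among the compounds named here.

Measured compounds:
- compound 1 `CN1CCC(c2c[nH]c3ccc(NC(=O)C4CC4)nc23)CC1`: 34 nM
- compound 2 `CN1CCC(c2c[nH]c3ccc(NC(=O)c4cccs4)nc23)CC1`: 15 nM

In a functional assay for activation of 5-hydroxytryptamine receptor 1F (Homo sapiens), read by GTPgammaS binding (on this read-out higher numbers stand for an effect only at larger amounts of compound and lower numbers for an effect already at smaller amounts), compound 2 gives the lower of the two numbers, with compound 1 giving a higher one a 2.3-fold lower number from compound 1 to compound 2 (0.36 log units; beyond the scatter). Compound 3 `CN1CCC(c2c[nH]c3ccc(NC(=O)c4ccncc4)nc23)CC1` carries the change (pyridin-4-yl in place of thiophen-2-yl on a carbonyl carbon). Going by the values given here, the only measured step, from compound 1 to compound 2, exchanged a cyclopropyl for an aromatic ring on the same carbonyl carbon and moved the number modestly; the step to compound 3 exchanges one aromatic ring for another, which the measured data do not cover. No change beyond the scatter is therefore expected, and compound 3 is estimated at 25 nM, between 8 nM and 80 nM, a step of a 1.7-fold higher number from compound 2 to compound 3 (0.22 log units; within the scatter).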

Compound 3, half-maximal effective concentration: 11 nM
Compound 3: middle estimate off by 2.3-fold (0.36 log units), on the high side, within the range that was stated.
By their numbers in this assay, from the lowest: compounds 3 and 2 (each within the scatter of the next); then compound 1.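

In this assay pyridin-4-yl takes the place of thiophen-2-yl on the carbonyl carbon with no change beyond the scatter (a 1.4-fold lower number from compound 2 to compound 3 (0.13 log units; within the scatter)), so a six-membered aromatic ring with a ring nitrogen and a five-membered one with sulfur give matching results here. Both aromatic rings stand apart from cyclopropyl, as the second step shows (a 3.1-fold lower number from compound 1 to compound 3 (0.49 log units; beyond the scatter)), and neither of these three compounds goes against that. Nothing available explains these results. Still open, as far as these compounds go, is how a plain phenyl ring or pyridin-3-yl would compare on this carbonyl carbon. Also open, from the compounds shown here alone, is whether a cyclohexyl ring would track cyclopropyl.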